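Trading a Primary Amide for a Bulky Carbamate

A few compounds are considered here, and "the series" means these few. Any claim that something is new, unique, unknown or untested is made for them only; others in the source may bear on it.

Compound 2 `NC(=O)c1ccccc1NC(=O)c1cc2ccccc2s1` is one of two measured members of this small set. In a physicochemical assay for solubility (on this read-out higher numbers stand for higher solubility and lower numbers for lower solubility), compound 2 gives < 5 ug/mL, which is a limit of the assay and not a number. Compound 1 `CC(C)(C)OC(=O)NCc1ccccc1NC(=O)c1cc2cc([N+](=O)[O-])ccc2s1` is the other measured member. In this assay compound 1 gives < 5 ug/mL, again a limit rather than a measured number. Compound 2 therefore stands at the floor of what the method reports, and the whole picture so far is captured by the limit of < 5 ug/mL in this assay, at which 2 of the 2 values shown sit.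

Compound 3 `CC(C)(C)OC(=O)NCc1ccccc1NC(=O)c1cc2ccccc2s1` has not yet been run in this assay. It differs from compound 2 in a single place: ((tert-butoxycarbonyl)amino)methyl in place of carbamoyl on an aromatic carbon. Going by the values given here, no measured step between compounds is available to anchor the size of this change. Since compound 2 already sits at the limit described by the limit of < 5 ug/mL in this assay, at which 2 of the 2 values shown sit, the step from compound 2 to compound 3 is expected to be small, a step that the limit leaves unreadable from compound 2 to compound 3, and within the usual scatter if anything. Compound 3 is expected to give about 3 ug/mL, with a likely range from 1 ug/mL to 10 ug/mL, most probably reported once more as a limit.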

Compound 3, solubility: 20 ug/mL
For compound 3 the middle estimate is 6.7-fold (0.82 log units) below the measured one, and the stated range ends below it.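

In this assay, going by these compounds alone, exchanging carbamoyl for ((tert-butoxycarbonyl)amino)methyl on this aromatic carbon comes with an at least 4.0-fold higher number from compound 2 to compound 3 (0.60 log units; beyond the scatter), and compound 3 gives the first value in the set that is a number and not a limit. This shows that the read-out at this position can move beyond the scatter, which the two earlier compounds could not show while both stood at a limit. The ((tert-butoxycarbonyl)amino)methyl group alone does not keep a compound at the floor either, since compound 1 carries it as well and hydrogen in place of nitro on an aromatic carbon comes with an at least 4.0-fold higher number from compound 1 to compound 3 (0.60 log units; beyond the scatter). Both steps give only a lower bound on the change and not its full size, since each starts from a limit: the limit of < 5 ug/mL in this assay, at which 2 of the 3 values shown sit.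

The compounds shown leave open how an aminomethyl group or a carboxylic acid on this same aromatic carbon would read in this assay, and so which part of the ((tert-butoxycarbonyl)amino)methyl group goes with the higher number. They also leave open whether an amine or a methoxy group in place of the nitro would stay at the limit, as compound 1 does, or would read like compound 3.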